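Cyano in place of fluoro on the benzyl ring

This account rests on a few compounds, and the source may have more. Where it says the series, first, only, none or still open, it means among the compounds named here.

Measured so far in an in vitro functional assay on cells for agonist activity at Bombesin receptor subtype-3 (Mus musculus), read by luminescence and calcium flux; a lower number here means that less compound is needed, a higher number that more compound is needed for the effect:
compound 1 `O=C(O)c1ccccc1-c1ccc(CCc2ncc(Cc3ccccc3F)[nH]2)cc1`: 9.5 nM
compound 2 `N#Cc1ccc(Cc2cnc(CCc3ccc(-c4ccccc4C(=O)O)cc3)[nH]2)cc1`: 723 nM
compound 3 `O=C(O)c1ccccc1-c1ccc(CCc2ncc(Cc3cccc(F)c3)[nH]2)cc1`: 7.9 nM

Compound 3 has the lowest number of the three, but the gap is only a 1.2-fold lower number from compound 1 to compound 3 (0.08 log units; within the scatter), so compound 1 and compound 3 cannot be told apart. Compound 2 stands far off: a 92-fold lower number from compound 2 to compound 3 (1.96 log units; beyond the scatter).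

Compound 4 `N#Cc1cccc(Cc2cnc(CCc3ccc(-c4ccccc4C(=O)O)cc3)[nH]2)c1` is compound 3 with cyano in place of fluoro on an aromatic carbon. Going by the values given here, no measured step isolates cyano against fluoro at one and the same position. The closest guide is the pair 1 and 2, where 4-cyanophenyl replaced 2-fluorophenyl and the number moved by a 76-fold higher number from compound 1 to compound 2 (1.88 log units; beyond the scatter); that step joins a change of group with a change of position, so only part of it may carry over. The step from compound 2 to compound 3 shows the same pair from the other side. A higher number for compound 4 than for compound 3 is therefore expected, probably beyond the scatter, with a wide range because the position is not the one tested.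

Estimate for compound 4: 120 nM, range 20 nM to 800 nM, a step of a 15-fold higher number from compound 3 to compound 4 (1.18 log units; beyond the scatter) from compound 3.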

Compound 4, half-maximal effective concentration: 20 nM
Compound 4: middle estimate off by 6.0-fold (0.78 log units), on the high side; the range from low to high includes it.
By their numbers in this assay, from the lowest: compounds 3 and 1 (each within the scatter of the next); then compound 4; then compound 2.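

In this assay, going by these compounds alone, a 2.5-fold higher number from compound 3 to compound 4 (0.40 log units; beyond the scatter) gives the only direct comparison of cyano and fluoro on the same aromatic carbon, and in the 3-substituted benzyl group the exchange costs only a modest amount. The step of a 36-fold lower number from compound 2 to compound 4 (1.56 log units; beyond the scatter) changes only the place of the cyano, from 4-cyanophenyl to 3-cyanophenyl, and its size shows that most of the large gap seen earlier with 4-cyanophenyl goes with that place and not with the presence of cyano as such. The modest step of a 2.1-fold higher number from compound 1 to compound 4 (0.32 log units; beyond the scatter) confirms that 3-cyanophenyl remains close to the 2-fluorophenyl compound, although still beyond the scatter, and no supporting data on the origin of these steps are at hand.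

Fluoro appears only in 2-fluorophenyl and 3-fluorophenyl, so it remains open whether the large loss with 4-cyanophenyl is specific to cyano or would also be seen with fluoro in that place. Also open, on these data alone, is how a methoxy group, an amine or a carboxylic acid on the same aromatic carbon would compare with fluoro and cyano.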